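Acyl chain extension on the aryl ether piperazine carbamate series

A few compounds are considered here, and "the series" means these few. Any claim that something is new, unique, unknown or untested is made for them only; others in the source may bear on it.

For the measured compounds named here, compound 3 `CCOC(=O)N1CCN(CCCOc2ccc(C(C)=O)cc2)CC1` gives 39800 nM in an assay on isolated protein for binding affinity to histamine H2 receptor (Homo sapiens) (on this read-out lower numbers stand for stronger inhibition and higher numbers for weaker inhibition), the highest of the three numbers measured so far. Compound 1 `CCCCCC(=O)c1ccc(OCCCN2CCN(C(=O)OC)CC2)cc1` gives 12000 nM in this assay, and compound 2 `CCCCCC(=O)c1ccc(OCCCN2CCN(S(=O)(=O)c3ccc(C#N)cc3)CC2)cc1` gives 12300 nM. Going by the values given here, the one single-point step measured, a 1.0-fold higher number from compound 1 to compound 2 (0.01 log units; within the scatter), concerns the group on the ring nitrogen and not the acyl chain, so it does not bear on the change considered here. Compound 1 and compound 3 differ in two places at once, the acyl chain and the carbamate alkyl, so their values can only be read side by side: compound 1 with the longer chain sits lower than compound 3.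

Compound 4 `CCOC(=O)N1CCN(CCCOc2ccc(C(=O)CC(C)C)cc2)CC1` is compound 3 with isopropyl in place of hydrogen on a saturated chain carbon bound to a carbonyl carbon, that is, acetyl to isobutylcarbonyl. Among the compounds with values here, no measured step isolates this change. Within the data shown here, the only guide is that compound 1, which carries a longer acyl chain, gives 12000 nM, a lower number than compound 3. On that basis the number for compound 4 is expected to move downward, as a 2.7-fold lower number from compound 3 to compound 4 (0.42 log units; beyond the scatter), with wide uncertainty. The estimate for compound 4 in this assay is 15000 nM, within a range of 6000 nM to 40000 nM.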

Compound 4, inhibition constant: 69200 nM
Estimate against measurement, compound 4: 4.6-fold (0.66 log units) below; the measured number lies above the stated range.
By their numbers in this assay, from the lowest: compounds 1 and 2 (each within the scatter of the next); then compounds 3 and 4 (each within the scatter of the next).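

Isopropyl in place of hydrogen on a saturated chain carbon bound to a carbonyl carbon, that is, acetyl to isobutylcarbonyl, gives the first reading of a change made only in the acyl chain in this assay, with a 1.7-fold higher number from compound 3 to compound 4 (0.24 log units; within the scatter) on the ethyl carbamate. That step lies within the scatter, so compound 3 and compound 4 cannot be told apart, and at this position the entry of isopropyl, with its 3 heavy atoms, has no effect that this assay can resolve. No measured information is available to account for this result.

The compounds shown leave open whether an unbranched longer chain on the carbonyl, or an amine or a carboxylic acid carried on the acyl chain, would shift the number beyond the scatter while the ethyl carbamate stays in place. They also leave open whether acetyl to isobutylcarbonyl reads the same when the ring nitrogen carries a group other than ethoxycarbonyl, such as an acetyl group or a benzyl group.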